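Swapping an Indole for a Methylthiophene on the Chain

The source may hold more compounds than are shown below. What is called first, only, known or untested is meant among the compounds shown, and "the series" means these compounds.

Three related compounds have been measured in a functional assay on DU-145 cells (Homo sapiens) for inhibition, read by trypan blue exclusion, with a stated time of 96 h; a higher number here means a weaker inhibitor of growth, a lower number a stronger inhibitor of growth. Compound 1 `Cc1ccsc1/C=C(/SCc1ccc(F)cc1)C(=O)c1ccc(Br)cc1` gives 50000 nM, and compound 2 `CC(=O)c1ccc(/C=C(/Sc2ccc(C)cc2)C(=O)c2ccc(Br)cc2)cc1` gives 50000 nM. Compound 3 `Cc1ccc(S/C(=C/c2c[nH]c3ccccc23)C(=O)c2ccc(Br)cc2)cc1` gives 10000 nM, the lowest of the three and therefore the strongest growth inhibitor so far; its steps to compound 1 and to compound 2 both lie beyond the scatter.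

Within the data shown here, the single measured step that changes the group on the chain is a 5.0-fold lower number from compound 2 to compound 3 (0.70 log units; beyond the scatter), showing that the indole group helps compared with the acetylphenyl group.

Compound 4 `Cc1ccc(S/C(=C/c2sccc2C)C(=O)c2ccc(Br)cc2)cc1` differs from compound 3 in one place: 3-methylthiophen-2-yl in place of 1H-indol-3-yl on a double-bonded chain carbon bound to a double-bonded chain carbon. Among the measured compounds shown here, no measured pair tests this exact exchange. The closest hint is compound 1, which carries the same 3-methylthiophen-2-yl group on a different sulfur substituent and gives 50000 nM, a number in the same region as compound 2. Taken together, removing the indole is expected to cost potency, likely by a step of similar size to the one seen from compound 2 to compound 3 but in the opposite direction.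

In this assay, compound 4 is therefore estimated at 35000 nM, with a range from 15000 nM to 80000 nM. The expected step is a 3.5-fold higher number from compound 3 to compound 4 (0.54 log units; beyond the scatter).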

Compound 4, concentration for 50% growth inhibition: 50000 nM
Beside the measured number, compound 4's estimate is 1.4-fold (0.15 log units) below it, within the range that was stated.
By their numbers in this assay, from the lowest: compound 3; then compounds 1, 2 and 4 (each within the scatter of the next).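

In this assay, the exchange of 1H-indol-3-yl for 3-methylthiophen-2-yl on a double-bonded chain carbon gives a 5.0-fold higher number from compound 3 to compound 4 (0.70 log units; beyond the scatter) and so tests this change directly within one matched pair. Exchanging 4-acetylphenyl for 3-methylthiophen-2-yl at the same place gives no change at the digits printed from compound 2 to compound 4 (within the scatter) in this assay, which means that, of the three groups compared at this position with 4-methylphenyl on the sulfur, only the indole separates from the others. On the sulfur, the exchange of 4-fluorobenzyl for 4-methylphenyl gives no change at the digits printed from compound 1 to compound 4 (within the scatter) when 3-methylthiophen-2-yl is on the chain, so this change on the sulfur has no readable effect in that setting.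

The indole differs from the thiophene both in carrying a hydrogen-bond donor and in having a second ring, and a 1-methyl-1H-indol-3-yl group at this position would help separate those two features. No independent measurement is available to explain the indole's lead in this series.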